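Trading methoxy for trifluoromethyl in an antiproliferative pair

The compounds below may be only part of what the source reports. "The series", "measured", "known", "first", "only" and "open" are said of these compounds alone.

Compound 1 `FC(F)(F)c1ccc2[nH]c(-c3cn(-c4ccccc4)nc3-c3ccccc3)nc2c1`: 5930 nM
Compound 2 `COc1ccc(-c2nn(-c3ccccc3)cc2-c2nc3cc(OC)ccc3[nH]2)cc1`: 22700 nM

In a functional assay on A549 cells (Homo sapiens) for antiproliferative activity, read by MTT assay, with a stated time of 48 h (a higher number here means a weaker inhibitor, a lower number a stronger inhibitor), compound 2 gives 22700 nM and so stands highest of the two numbers, the weaker of the pair. Compound 1 gives 5930 nM in this assay and the gap between the two lies beyond the usual scatter.

The next compound to be read is compound 3 `COc1ccc(-c2nn(-c3ccccc3)cc2-c2nc3cc(C(F)(F)F)ccc3[nH]2)cc1`, which differs from compound 2 in one place. It has trifluoromethyl in place of methoxy on an aromatic carbon of a six-membered aromatic ring of carbon only, part of a fused or bridged system of two rings.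

Within the data shown here, no measured pair differs in a single place, so no direct precedent for this change exists. Among the measured compounds shown here, the only guide is compound 1, the one measured compound bearing trifluoromethyl, at 5930 nM and this points to a lower number, though the evidence is thin. A moderate gain in potency is therefore expected, and it may not clear the scatter by much (a 2.3-fold lower number from compound 2 to compound 3 (0.36 log units; beyond the scatter)). The estimate for compound 3 is 10000 nM (expected range 3500 nM to 28000 nM).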

Compound 3, half-maximal inhibitory concentration: 4820 nM
Beside the measured number, compound 3's estimate is 2.1-fold (0.32 log units) above it; the range from low to high includes it.
By their numbers in this assay, from the lowest: compounds 3 and 1 (each within the scatter of the next); then compound 2.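

In this assay, among these compounds, the first comparison at this position that changes one place only shows that trifluoromethyl in place of methoxy, on an aromatic carbon of a six-membered aromatic ring of carbon only, part of a fused or bridged system of two rings, gives a 4.7-fold lower number from compound 2 to compound 3 (0.67 log units; beyond the scatter), so the number responds to this exchange. The second such comparison, methoxy in place of hydrogen on an aromatic carbon, gives a 1.2-fold lower number from compound 1 to compound 3 (0.09 log units; within the scatter), so with trifluoromethyl held in place, that methoxy does not separate the two compounds. No measurement among those at hand speaks to what lies behind the step from methoxy to trifluoromethyl.

The compounds shown carry only methoxy and trifluoromethyl at this position, so it remains open whether an amine, a carboxylic acid or a chlorine atom there would read closer to compound 2 or to compound 3. On these data alone, it also remains open whether a hydroxyl group or a longer alkoxy chain on the aromatic carbon that holds methoxy in compound 3 would leave the number equally unmoved.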